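A few compounds are considered here, and "the series" means these few. Any claim that something is new, unique, unknown or untested is made for them only; others in the source may bear on it.

Values in a functional assay on RAW264.7 cells (Mus musculus) for inhibition, read by Griess assay, with a stated time of 20 h; on this read-out lower numbers stand for stronger inhibition and higher numbers for weaker inhibition:
compound 1 `CCCCCCc1cn(-c2ccc(O)c(C(=O)NCCC)c2)nn1`: 19700 nM
compound 2 `O=C(c1cc(-n2cc(-c3ccccc3)nn2)ccc1O)N1CCCCC1`: > 20000 nM (a limit)
compound 3 `CCCCCCc1cn(-c2ccc(O)c(C(=O)N3CCCCC3)c2)nn1`: > 20000 nM (a limit)

Compound 3 gives no number, only the limit > 20000 nM. Readings in this series gather at the limit of > 20000 nM in this assay, at which 2 of the 3 values shown sit.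

The next compound, compound 4 `O=C(c1cc(-n2cc(-c3cc(F)cc(F)c3)nn2)ccc1O)N1CCCCC1`, has not yet been measured. Its difference from compound 3 is 3,5-difluorophenyl in place of hexyl on an aromatic carbon. In words, it has 3,5-difluorophenyl in place of hexyl on an aromatic carbon.

Among the compounds with values here, two measured steps bear on this. The closer one concerns the same place, with hexyl in place of phenyl, and it is a step that the two limits leave unreadable from compound 2 to compound 3. The other, piperidin-1-yl in place of propylamino on a carbonyl carbon, is an at least 1.0-fold higher number from compound 1 to compound 3 (0.00 log units; that floor lies within the scatter). Compound 2, which carries phenyl at this place, also stops at the limit > 20000 nM.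

With no readable step to build on, the expected change is no more than the scatter, and the estimate is a step that the limit leaves unreadable from compound 3 to compound 4. Compound 4 is expected near 22000 nM, with an estimated range of 10000 nM to 45000 nM, and the assay may well report only a limit.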

Compound 4, half-maximal inhibitory concentration: > 20000 nM
Compound 4 ended at the assay's limit; the forecaster's own chance of this, stated with the estimate: 70%; the middle value lies beyond the limit too.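

Compound 4 gives only a limit (> 20000 nM). Compound 2 and compound 3 also stop at limits, so no step among these three compounds can be read. Going by these compounds, whether phenyl, hexyl and 3,5-difluorophenyl at this place differ at all in inhibition remains open.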